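A Bromine Added to the Phenyl of Compound 3

A few compounds are considered here, and "the series" means these few. Any claim that something is new, unique, unknown or untested is made for them only; others in the source may bear on it.

Of the compounds shown here, three have been measured in a functional assay on corpus cavernosum (Rattus norvegicus) for activation; a lower number here means a smaller maximal response, a higher number a larger maximal response. Compound 1 `O=c1[nH]c(-c2ccccc2O)nc2c1cnn2-c1ccccc1` gives 93%. Compound 2 `CCCOc1ccccc1-c1nc2c(cnn2-c2ccc(Br)cc2)c(=O)[nH]1` gives 140%. Compound 3 `O=c1[nH]c(CNc2ccccc2O)nc2c1cnn2-c1ccccc1` gives 125%, which places it second among the three: compound 2 lies higher, beyond the scatter, and compound 1 lies lower, also beyond the scatter. Compound 2 and compound 1 differ in more than one place, so their values are set side by side without a single step being read from them.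

Compound 4 `O=c1[nH]c(CNc2ccccc2O)nc2c1cnn2-c1ccc(Br)cc1` is not yet measured. It differs from compound 3 in one place: bromo in place of hydrogen on an aromatic carbon, or, taken one bond further out, phenyl to 4-bromophenyl. Among the compounds with values here, the only other compound that carries a 4-bromophenyl, compound 2, has the highest number of the three in this assay, while the two with plain phenyl, compound 1 and compound 3, sit lower. Within the data shown here, no pair in the set isolates this change, so the expectation rests on this indirect comparison.

Compound 4 is expected to give 135% in this assay, within 105% to 165%. The step of a number 10 percentage points higher from compound 3 to compound 4 (within the scatter) that this estimate implies is a modest rise, close to the edge of the scatter.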

Compound 4, largest response reached (Emax), in percent of the reference or control that the assay uses: 133%
For compound 4 the middle estimate is 2 percentage points above the measured one; measured number inside the range.
By their numbers in this assay, from the lowest: compound 1; then compounds 3, 4 and 2 (each within the scatter of the next, the first and the last beyond it).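

Within the data shown here, compound 3 and compound 4 are the first pair in the set that isolates bromo in place of hydrogen on an aromatic carbon, and in this assay this change gives a number 8 percentage points higher from compound 3 to compound 4 (within the scatter). The maximal response therefore survives phenyl to 4-bromophenyl, but this single step does not separate the two compounds, so it shows no gain from the bromo. Nothing available explains this result.

The compounds shown leave open whether a different group on the same aromatic carbon, such as a methoxy, a nitrile or a carboxylic acid, would take the response beyond the scatter of compound 3. They also leave open whether the same bromo would give a similar step on the core of compound 1.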